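Swapping the bicyclic group for an aminopyridine

A few compounds are considered here, and "the series" means these few. Any claim that something is new, unique, unknown or untested is made for them only; others in the source may bear on it.

Measured compounds:
compound 1 `COc1n[nH]c2ncc(-c3nc(-c4c(F)ccc(NS(=O)(=O)c5cccc(Cl)c5)c4F)no3)cc12` gives 29 nM in an assay on Sf9 cells for inhibition of mitogen-activated protein kinase kinase kinase 20 (Homo sapiens), read by ADP-Glo, with a stated time of 30 min; on this read-out lower numbers stand for stronger inhibition and higher numbers for weaker inhibition
compound 2 `COc1n[nH]c2ncc(-c3cn(-c4c(F)ccc(NS(=O)(=O)c5cccc(Cl)c5)c4F)nn3)cc12` gives 1.9 nM in this assay

Compound 2 stands lowest of the two numbers; the nearest is compound 1, whose number is higher by a margin beyond the scatter. Compound 3 `Nc1ccc(-c2cn(-c3c(F)ccc(NS(=O)(=O)c4cccc(Cl)c4)c3F)nn2)cn1` is not yet measured. The change from compound 2 to compound 3 is a group of 7 heavy atoms (5 carbon, 2 nitrogen; one six-membered aromatic ring with 1 hetero atom) in place of a group of 11 heavy atoms (7 carbon, 3 nitrogen, 1 oxygen; one five-membered aromatic ring with 2 hetero atoms, one six-membered aromatic ring with 1 hetero atom), on an aromatic carbon. Within the data shown here, no comparable step between measured compounds exists, so the direction of the change rests on judgement alone; a moderate loss, larger than the scatter, is expected as the step from compound 2 to compound 3, a 7.9-fold higher number from compound 2 to compound 3 (0.90 log units; beyond the scatter). Compound 3 is estimated at 15 nM, with a range from 3 nM to 80 nM.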

Compound 3, half-maximal inhibitory concentration: 46.2 nM
The estimate for compound 3 lay 3.1-fold (0.49 log units) below the measured number; the measured number falls inside the stated range.
By their numbers in this assay, from the lowest: compound 2; then compounds 1 and 3 (each within the scatter of the next).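

In this assay, putting 6-aminopyridin-3-yl on the five-membered aromatic ring with 3 nitrogen gives a 24-fold higher number from compound 2 to compound 3 (1.39 log units; beyond the scatter), a large loss. This position therefore does not treat the smaller single-ring group as an equal of the group that leaves, although compound 3 still reads 46.2 nM. Nothing available here bears on the reason for this loss. The compounds shown leave open whether the amine itself matters at this position, and whether a plain phenyl ring or a 6-methoxypyridin-3-yl group would read closer to compound 2.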